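The source may report more compounds than this note shows. Statements on the series, on what has been measured and on what is new or still open speak of the compounds shown alone.

Measured in a functional assay on HL-60 cells (Homo sapiens) for antiproliferative activity; on this read-out higher numbers stand for weaker inhibition and lower numbers for stronger inhibition:
- Compound 1 `COc1ccc(O)c2c(O)ccnc12`: 17700 nM
- Compound 2 `COc1ccc(OC)c2c(O)ccnc12`: > 30000 nM, a limit
- Compound 3 `COc1cc2nccc(O)c2c(O)c1OC`: > 30000 nM, a limit

Compound 2 has no exact number. Its result of > 30000 nM is a limit of the assay. Compound 2 therefore belongs to the limit of > 30000 nM in this assay, at which 2 of the 3 values shown sit, and compound 3 is the other compound there.

Compound 4 `COc1ccc(C)c2nccc(O)c12` differs from compound 2 in one place: methyl in place of methoxy on an aromatic carbon. The swap is methyl in place of methoxy on an aromatic carbon, para to a methoxy group.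

For the measured compounds named here, no measured step makes this swap. The closest evidence is an at least 1.6-fold higher number from compound 1 to compound 2 (0.22 log units; that floor lies within the scatter), which comes from a different change, methyl in place of hydrogen on an oxygen on an aromatic ring. Its size therefore cannot be carried over directly, and it offers no sign of a large shift. In this assay, the expectation is no step beyond the scatter, and no direction can be read from a limit. Compound 4 may well return a limit too.

For compound 4, the estimated value is 30000 nM, with an expected range from 14000 nM to 60000 nM. This estimate means an expected a number no higher from compound 2 to compound 4 (the limit leaves the size open).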

Compound 4, half-maximal inhibitory concentration: > 30000 nM
Compound 4: only a limit was reported; the forecaster's own chance of this, stated with the estimate: 60%; the middle value sits exactly at the limit.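

In this assay compound 2 and compound 4 each gave only a limit, not a number, so no step can be read between them. Both sit at the same limit: the limit of > 30000 nM in this assay, at which 3 of the 4 values shown sit. The compounds shown leave open how strongly compound 2 and compound 4 really inhibit, and whether methyl in place of methoxy changes that at all.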